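The compounds below may be only part of what the source reports. "The series", "measured", "known", "first", "only" and "open" are said of these compounds alone.

Measured so far in a functional assay on the whole organism (strain Kunming) for inhibition, with Mus musculus as the target, in the writhing test, at a dose of 40 mg/kg by the oral route; a lower number here means less inhibition, a higher number more inhibition at the dose given (going by the name of the read-out):
compound 1 `O=C(Oc1ccc(-c2ccc(F)cc2F)cc1C(=O)O)c1ccccc1`: 7.97%
compound 2 `CC(=O)Oc1ccc(-c2ccc(F)cc2F)cc1C(=O)NC1CCCCC1`: 15.6%

Compound 2 holds the higher of the two numbers, but its gap to compound 1 sits within the scatter, so the two values cannot be ordered. Compound 3 `CC(=O)Oc1ccc(-c2ccc(F)cc2F)cc1C(=O)NN1CCOCC1` follows from compound 2 by morpholin-4-yl in place of cyclohexyl on an amide-type nitrogen. Going by the values given here, no step between measured compounds bears on this change, and the two values shown give no pull in either direction. The step is expected to stay within the scatter: a number 1.6 percentage points lower from compound 2 to compound 3 (within the scatter). Compound 3 is accordingly estimated at 14%, with a range from 3% to 30%.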

Compound 3, a percentage reported as inhibition, in the whole organism at one dose (the size of the read-out at that dose, not a potency): 28.5%
Compound 3: the middle estimate sits 14.5 percentage points below what was measured, within the range that was stated.
By their numbers in this assay, from the lowest: compounds 1 and 2 (each within the scatter of the next); then compound 3.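

In this assay the group on the amide-type nitrogen matters: a number 12.9 percentage points higher from compound 2 to compound 3 (beyond the scatter), a modest step with morpholin-4-yl in place of cyclohexyl. Both groups are six-membered non-aromatic rings of 6 heavy atoms, so the step comes with ring hetero atoms and no change in heavy-atom count. No measurement at hand accounts for the step. Which hetero atom carries the step stays open: piperidin-1-yl on the same nitrogen would separate the ring oxygen from the nitrogen. From the compounds shown here alone, whether the ring is needed at all also stays open, and an open-chain dimethylamino group would address that.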